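Compound 1 to compound 3: methyl to 4-fluorobenzyl

The source may report more compounds than this note shows. Statements on the series, on what has been measured and on what is new or still open speak of the compounds shown alone.

Compound 1 `CCOC(=O)c1ccc(-c2nn(C)c3ccccc23)cc1` is the starting point of this step. In a functional assay on cells (Platelet, Homo sapiens) for inhibition (a lower number here means a stronger inhibitor, a higher number a weaker inhibitor), compound 1 gives > 10000 nM, which is a limit and not a number. From the compounds shown here alone, its true position therefore remains unknown.

Compound 3 `CCOC(=O)c1ccc(-c2nn(Cc3ccc(F)cc3)c3ccccc23)cc1` differs from it as follows: 4-fluorophenyl in place of hydrogen on a saturated chain carbon bound to an aromatic nitrogen. In words, 4-fluorophenyl replaces hydrogen on a saturated chain carbon bound to an aromatic nitrogen.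

Among the measured compounds shown here, the only measured step that bears on this change is the one to compound 2 `CCOC(=O)c1ccc(-c2nn(Cc3ccccc3F)c3ccccc23)cc1`, which carries 2-fluorophenyl at that place. Compound 2 gives > 10000 nM, also a limit. That change is recorded as a step that the two limits leave unreadable from compound 1 to compound 2, so it offers no size to carry over. The evidence so far is the limit of > 10000 nM in this assay, at which 2 of the 2 values shown sit.

No clear step is therefore expected in this assay, and no direction can be firmly assigned. The most likely outcome is another limit, although a weak measurable inhibition cannot be excluded.

For compound 3, the expected value is 15000 nM, with an estimated range of 4000 nM to 40000 nM. The expected change is a step that the limit leaves unreadable from compound 1 to compound 3.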

Compound 3, half-maximal inhibitory concentration: > 10000 nM
Compound 3: no number, only a limit (the forecaster's own chance of this, stated with the estimate: 80%); the middle value is on the limit's open side.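

Among the compounds shown here, no step among compound 1, compound 2 and compound 3 can be read in this assay. Compound 3 gives > 10000 nM, which is a limit and not a number. The compounds shown leave open how far each lies beyond that limit, and whether 4-fluorophenyl and 2-fluorophenyl differ from each other or from hydrogen in this read-out.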